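This account rests on a few compounds, and the source may have more. Where it says the series, first, only, none or still open, it means among the compounds named here.

Of the compounds shown here, three from one series have been measured in a functional assay on gastric mucosa for displacement of a labelled ligand from Gastrin/cholecystokinin type B receptor (Canis lupus familiaris), read by CCK-8 assay; on this read-out higher numbers stand for weaker inhibition and lower numbers for stronger inhibition. Compound 1 `O=C(CN1N=C(C2CCCCC2)c2ccccc2N(CC(=O)C2CCCC2)C1=O)Nc1cccc(C(=O)O)c1` gives 7.08 nM. Compound 2 `CC(C)(C)C(=O)CN1C(=O)N(CC(=O)Nc2cccc(-c3nc(=O)o[nH]3)c2)N=C(C2CCCCC2)c2ccccc21` gives 4.47 nM. Compound 3 `CC(C)(C)C(=O)CN1C(=O)N(CC(=O)Nc2cccc(-c3nn[nH]n3)c2)N=C(C2CCCCC2)c2ccccc21` gives 3.16 nM, the lowest of the three numbers, though its gap to compound 2 lies within the scatter and only its gap to compound 1 lies beyond it.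

Compound 4 `CC(C)(C)C(=O)CN1C(=O)N(CC(=O)Nc2cccc(CC(=O)O)c2)N=C(C2CCCCC2)c2ccccc21` has not yet been measured. It differs from compound 3 in one place: carboxymethyl in place of 2H-tetrazol-5-yl on an aromatic carbon. Among the measured compounds shown here, no measured step swaps an aromatic ring for an open acid chain. The nearest step, a 1.4-fold lower number from compound 2 to compound 3 (0.15 log units; within the scatter), exchanges one five-membered aromatic ring for another and stays within the scatter. Compound 1 carries a carboxylic acid directly on the ring and also differs elsewhere, so it shows only that an acid on that ring can give a number near 7.08 nM.

Weighing this, compound 4 is expected to come out somewhat weaker, a step of a 3.2-fold higher number from compound 3 to compound 4 (0.50 log units; beyond the scatter). The estimate for compound 4 is 10 nM, with a range from 4 nM to 25 nM.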

Compound 4, inhibition constant: 5.25 nM
Beside the measured number, compound 4's estimate is 1.9-fold (0.28 log units) above it, within the range that was stated.
By their numbers in this assay, from the lowest: compounds 3, 2, 4 and 1 (each within the scatter of the next, the first and the last beyond it).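

In this assay, the place on the aromatic ring that held 2H-tetrazol-5-yl also tolerates carboxymethyl, an open chain with no ring: a 1.7-fold higher number from compound 3 to compound 4 (0.22 log units; within the scatter), and a 1.2-fold higher number from compound 2 to compound 4 (0.07 log units; within the scatter). Among the compounds shown here, the earlier compounds showed only one five-membered aromatic ring exchanged for another, whereas compounds 2, 3 and 4 now show that neither ring is needed at this place for a number in this range, with no step among the three beyond the scatter. No measurement at hand bears on the reason these three groups read alike.

The compounds shown leave open how an amine or a longer acid chain, such as carboxyethyl, would read at this place. They also leave open whether the number would hold with a methyl ester in place of the free carboxylic acid.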